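The compounds below may be only part of what the source reports. "The series", "measured", "known", "first", "only" and "open" are said of these compounds alone.

Two members of the series carry a measurement in an ADME assay on BEAS-2B cells (Homo sapiens) for cytotoxicity, read by MTT assay, with a stated time of 72 h; a higher number here means a weaker inhibitor of growth, a lower number a stronger inhibitor of growth. Compound 1 `COc1ccc(OC(=O)Nc2ccc([Se]C#N)cc2)cc1` gives 25200 nM in this assay. Compound 2 `CCCOC(=O)Nc1ccc([Se]C#N)cc1` gives 19200 nM in this assay, the lower of the two numbers, although its gap to compound 1 lies within the scatter. Compound 3 `CCCCOC(=O)Nc1ccc([Se]C#N)cc1` is not yet measured and differs from compound 2 by methyl in place of hydrogen on a saturated chain carbon, three bonds along the chain from an oxygen next to a carbonyl group. Within the data shown here, no measured pair shows a step of this kind, so nothing beyond the scatter is expected in this assay, in either direction. For compound 3 a value of 17000 nM is estimated, with a range from 8000 nM to 40000 nM. The estimated step of a 1.1-fold lower number from compound 2 to compound 3 (0.05 log units; within the scatter) is expected to stay within the scatter.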

Compound 3, concentration for 50% growth inhibition: 5000 nM
Estimate against measurement, compound 3: 3.4-fold (0.53 log units) above; the whole stated range lies above it.
By their numbers in this assay, from the lowest: compound 3; then compounds 2 and 1 (each within the scatter of the next).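

In this assay, among these compounds, the change of propyl to butyl gives a 3.8-fold lower number from compound 2 to compound 3 (0.58 log units; beyond the scatter) and is the first step read at this place, so a single added methyl, three bonds along the chain from an oxygen next to a carbonyl group, can move the number beyond the scatter. The saturated chain is therefore not a silent part of the series in this assay. Nothing measured here accounts for the step.

Going by these compounds, whether a longer chain such as pentyl extends the step, or a branched chain or terminal amine matches it, stays open. One step at this place does not establish a trend along the chain.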